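Replacing the propyl group of compound 3 with bromine

The source may report more compounds than this note shows. Statements on the series, on what has been measured and on what is new or still open speak of the compounds shown alone.

Measured so far:
compound 1 `C=CCc1ccccc1OCC1=NCCN1`, 977 nM;
compound 2 `c1ccc(OCC2=NCCN2)c(CC2CC2)c1`, 1700 nM;
compound 3 `CCCc1ccccc1OCC1=NCCN1`, 2510 nM.

All three share one core and differ only in the group on the chain carbon attached to the ring. In an assay on isolated protein for agonist activity at Alpha-2B adrenergic receptor (Homo sapiens) (on this read-out higher numbers stand for an effect only at larger amounts of compound and lower numbers for an effect already at smaller amounts), compound 3 has the highest number of the three: a 1.5-fold higher number from compound 2 to compound 3 (0.17 log units; within the scatter), while a 2.6-fold higher number from compound 1 to compound 3 (0.41 log units; beyond the scatter). Compound 4 `Brc1ccccc1OCC1=NCCN1` changes the ring itself: bromo in place of propyl on an aromatic carbon. Among the compounds with values here, none of the measured steps touches an aromatic carbon, so the closest guides are the small chain steps already seen, such as a 1.7-fold higher number from compound 1 to compound 2 (0.24 log units; within the scatter). The expected step is therefore modest, a 1.7-fold lower number from compound 3 to compound 4 (0.22 log units; within the scatter), with wide uncertainty. Compound 4 is estimated at 1500 nM, between 300 nM and 8000 nM.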

Compound 4, half-maximal effective concentration: 1260 nM
Beside the measured number, compound 4's estimate is 1.2-fold (0.08 log units) above it, within the range that was stated.
By their numbers in this assay, from the lowest: compounds 1, 4, 2 and 3 (each within the scatter of the next, the first and the last beyond it).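

With a single bromine atom on the aromatic carbon in place of a chain of three carbons, the read-out stays within the scatter: a 2.0-fold lower number from compound 3 to compound 4 (0.30 log units; within the scatter). The same holds against the other two chains, with a 1.3-fold lower number from compound 2 to compound 4 (0.13 log units; within the scatter) and a 1.3-fold higher number from compound 1 to compound 4 (0.11 log units; within the scatter), so at this position a halogen serves about as well as any of these carbon groups. Nothing available explains this result. From the compounds shown here alone, whether an amine, a carboxylic acid or a longer chain on this aromatic carbon would stay in the same range remains open.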